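Chalcone-type series: aryl swap on the carbonyl

The compounds below may be only part of what the source reports. "The series", "measured", "known", "first", "only" and "open" are said of these compounds alone.

Measured compounds:
compound 1 `COc1cc(-c2cc(/C=C/C(=O)c3ccc(N)cc3)[nH]n2)cc(OC)c1OC` gives -85% in a functional assay on MDA-MB-435 cells (Homo sapiens) for cytotoxicity, read by sulforhodamine B assay, with a stated time of 48 h, tested at 100 uM; on this read-out higher numbers stand for a weaker effect at the one concentration tested and lower numbers for a stronger effect
compound 2 `COc1ccc(-c2cc(/C=C/C(=O)c3ccc(OC)c(OC)c3)[nH]n2)cc1` gives -91% in this assay

Compound 1 stands at the higher of the two numbers recorded, with compound 2 the nearest and only comparator; the gap between them lies within the scatter, so the two cannot be ordered.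

Compound 3 `COc1cc(-c2cc(/C=C/C(=O)c3ccc(Cl)c(Cl)c3)[nH]n2)cc(OC)c1OC` is not yet measured. It differs from compound 1 as follows: 3,4-dichlorophenyl in place of 4-aminophenyl on a carbonyl carbon. For the measured compounds named here, no measured pair shows this kind of change, so no step size is known.

Given that compound 1 and compound 2 both sit at strongly negative readings in this assay despite different substitution at both ends, the step is expected to be small, in either direction or none beyond the scatter; compound 3 is estimated at -80% (range -95% to -50%), which means an expected step of a number 5 percentage points higher from compound 1 to compound 3 (within the scatter).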

Compound 3, a percentage reported as activity, at one concentration (the size of the read-out at that concentration, not a potency): 6%
For compound 3 the middle estimate is 86 percentage points below the measured one; measured number outside the range, above it.
By their numbers in this assay, from the lowest: compounds 2 and 1 (each within the scatter of the next); then compound 3.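

The aryl group on a carbonyl carbon is a sensitive place in this assay: replacing 4-aminophenyl with 3,4-dichlorophenyl, with the rest of the structure unchanged, gives a number 91 percentage points higher from compound 1 to compound 3 (beyond the scatter). This single swap removes the amine and adds both chlorines, so it does not show which of these changes accounts for the step. Nothing available here bears on the reason for the step.

Open, as far as these compounds go, is whether the loss of the amine or the arrival of the chlorines carries the step, which a plain phenyl or a 4-chlorophenyl on the same carbonyl carbon of the core of compound 1 would help to separate. Also open, from the compounds shown here alone, is whether the same swap would give a step of similar size on the core of compound 2.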